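Tertiary Alcohol in Place of a Primary One

The source may hold more compounds than are shown below. What is called first, only, known or untested is meant among the compounds shown, and "the series" means these compounds.

Compound 1 `CCCC[S+]([O-])c1sc2nc(-c3ccccc3)nc(-c3ccccc3)c2c1N` gives 4.9 nM in an assay for inhibition of 15-hydroxyprostaglandin dehydrogenase [NAD(+)] (Homo sapiens), read by fluorescence, with a stated time of 15 min, in the presence of a further agent that is not named here; on this read-out lower numbers stand for stronger inhibition and higher numbers for weaker inhibition.
Compound 2 `CCCC[S+]([O-])c1sc2nc(-c3nccs3)cc(-c3ccc(CCO)cc3)c2c1N` gives 2.9 nM in this assay.
Compound 3 `CCC[S+]([O-])c1sc2nc(-c3cccs3)cc(C(=O)N(C)C)c2c1N` gives 14.7 nM in this assay.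

Of the three numbers, compound 2 gives the lowest. Compound 1 lies close to it, within the usual scatter of the measurement, so no order can be read between the two, while compound 3 stands at a higher number beyond the scatter. Compound 4 `CCCC[S+]([O-])c1sc2nc(-c3nccs3)cc(-c3ccc(C(C)(C)O)cc3)c2c1N` has not yet been measured. It differs from compound 2 in one place: 1-hydroxy-1-methylethyl in place of 2-hydroxyethyl on an aromatic carbon. Going by the values given here, no measured pair shows the effect of this change, so the expectation rests on compound 2 alone. Because compound 2 gives 2.9 nM, the step of a 1.2-fold higher number from compound 2 to compound 4 (0.08 log units; within the scatter) is expected to be small, without a direction beyond the scatter. Compound 4 is therefore estimated at 3.5 nM, with a range from 1.5 nM to 9 nM.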

Compound 4, half-maximal inhibitory concentration: 3.6 nM
Estimate against measurement, compound 4: 1.0-fold (0.01 log units) below; the range from low to high includes it.
By their numbers in this assay, from the lowest: compounds 2, 4 and 1 (each within the scatter of the next); then compound 3.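

In this assay, 1-hydroxy-1-methylethyl in place of 2-hydroxyethyl gives a 1.2-fold higher number from compound 2 to compound 4 (0.09 log units; within the scatter), so the tertiary and the primary alcohol cannot be told apart at this position. Going by these compounds alone, this is the first pair here that differs in one place, and it shows that 4-(1-hydroxy-1-methylethyl)phenyl serves as well as 4-(2-hydroxyethyl)phenyl on this core. No measurement is at hand that would explain this result.

From the compounds shown here alone, what an amine, a carboxylic acid or a plain methyl would give at this position stays open. So does whether this step would read the same on the cores of compound 1 or compound 3.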